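The source may report more compounds than this note shows. Statements on the series, on what has been measured and on what is new or still open speak of the compounds shown alone.

The shared core of compound 2 `CCOc1ccc(CN2CCC(C(=O)Nc3cc(Cl)c(N)cc3OC)CC2)cc1` carries a 4-ethoxyphenyl on a saturated chain carbon bound to an amine nitrogen in a ring. In a functional assay on the whole organism for antagonist activity, with Mus musculus as the target (on this read-out lower numbers stand for an effect already at smaller amounts and higher numbers for an effect only at larger amounts of compound), compound 2 gives 6.3 mg/kg. Among the compounds with values here, this is the only number among the three values in hand. Compound 1 `COc1cc(N)c(Cl)cc1NC(=O)C1CCN(Cc2cccc(C#N)c2)CC1` reaches only a limit in this assay, > 4 mg/kg. Compound 3 `COc1cc(N)c(Cl)cc1NC(=O)C1CCN(Cc2ccc(O)cc2)CC1` likewise reaches only a limit, > 8 mg/kg. The step that the limit leaves unreadable from compound 1 to compound 2 and the step that the two limits leave unreadable from compound 1 to compound 3 are therefore not readable, the first because of the limit of > 4 mg/kg in this assay, at which 1 of the 3 values shown sits, and the second because of the limit of > 4 mg/kg in this assay, at which 1 of the 3 values shown sits, together with the limit of > 8 mg/kg in this assay, at which 1 of the 3 values shown sits. The step of an at least 1.2-fold higher number from compound 2 to compound 3 (0.10 log units; that floor lies within the scatter) has a floor that lies within the scatter.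

Compound 4 `COc1cc(N)c(Cl)cc1NC(=O)C1CCN(Cc2ccc(F)cc2)CC1` has not been measured. It differs from compound 2 by fluoro in place of ethoxy on an aromatic carbon. None of the readable steps bears directly on this change: the exchange of 4-ethoxyphenyl for 4-hydroxyphenyl gives only a floor, and the other two steps are masked by limits. The estimate for compound 4 in this assay can thus only be anchored on compound 2, with the step of a 1.3-fold higher number from compound 2 to compound 4 (0.10 log units; within the scatter) expected to be small. Compound 4 is therefore estimated at 8 mg/kg, with a range from 3 mg/kg to 25 mg/kg.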

Compound 4, dose for half-maximal effect: 0.6 mg/kg
The estimate for compound 4 lay 13-fold (1.12 log units) above the measured number; the whole stated range lies above it.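

Within the data shown here, at this carbon of the aromatic ring, para to a large group, fluoro in place of ethoxy gives an 11-fold lower number from compound 2 to compound 4 (1.02 log units; beyond the scatter) in this assay, the first step with a number on both sides that lies beyond the scatter, so the group held here clearly matters in this whole-animal read-out. Fluoro in place of hydroxy on the same carbon gives an at least 13-fold lower number from compound 3 to compound 4 (1.12 log units; beyond the scatter), a step that is only a floor, as compound 3 reaches a limit and not a number: the limit of > 8 mg/kg in this assay, at which 1 of the 4 values shown sits. The change to 4-fluorophenyl from 3-cyanophenyl gives an at least 6.6-fold lower number from compound 1 to compound 4 (0.82 log units; beyond the scatter), again only a floor, as compound 1 also reaches a limit and not a number: the limit of > 4 mg/kg in this assay, at which 1 of the 4 values shown sits.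

On these data alone, the steps from compound 1 to compound 2 and to compound 3 still cannot be read, so the order of those two changes stays unknown. Whether the low number of compound 4 needs fluoro itself remains open, as the compounds shown do not tell how a chloro, a methyl or a plain hydrogen on this carbon would compare.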